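This account rests on a few compounds, and the source may have more. Where it says the series, first, only, none or still open, it means among the compounds named here.

Compound 1 `COc1cc(OC)c2c(=O)cc(-c3ccc(OCCN4CCCC4=O)cc3)oc2c1`: 14%
Compound 2 `COc1cc(OC)c2c(=O)cc(-c3ccc(OCC(O)CN4CCCC4)cc3)oc2c1`: 37%

Among the compounds with values here, in a functional assay (Homo sapiens) for antiproliferative activity, read by resazurin assay, with a stated time of 48 h, tested at 10 uM (a higher number here means a stronger effect of the compound at the concentration tested, a lower number a weaker effect), compound 1 gives 14%, the lower of the two measured numbers; compound 2 gives 37%, and the single measured step is a number 23 percentage points higher from compound 1 to compound 2 (beyond the scatter). Compound 3 `COc1cc(OC)c2c(=O)cc(-c3ccc(Br)cc3)oc2c1` has not yet been measured. The change from compound 1 to compound 3 is bromo in place of 2-(2-oxopyrrolidin-1-yl)ethoxy on an aromatic carbon. Within the data shown here, no measured step bears on this change: the step from compound 1 to compound 2 exchanged one chain end for another and removed nothing. The expectation is therefore uncertain, and a number 4 percentage points higher from compound 1 to compound 3 (within the scatter) is estimated to stay within the scatter. Compound 3 is expected to give 18%, between 0% and 42%.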

Compound 3, a percentage reported as inhibition, at one concentration (the size of the read-out at that concentration, not a potency): 10%
For compound 3 the middle estimate is 8 percentage points above the measured one; the measured number falls inside the stated range.
By their numbers in this assay, from the lowest: compounds 3 and 1 (each within the scatter of the next); then compound 2.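

In this assay, bromo in place of 2-(2-oxopyrrolidin-1-yl)ethoxy gives a number 4 percentage points lower from compound 1 to compound 3 (within the scatter), so at this aromatic carbon a single bromine atom and the whole chain of compound 1 cannot be told apart. Against the 2-hydroxy-3-(pyrrolidin-1-yl)propoxy chain, the same bromo gives a number 27 percentage points lower from compound 2 to compound 3 (beyond the scatter), which sets compound 2 alone apart among these compounds. No evidence at hand accounts for this difference. Still open, from the compounds shown here alone, is whether a 2-(pyrrolidin-1-yl)ethoxy chain, lacking both the carbonyl and the hydroxyl, would read like compound 2, and whether a carboxylic acid at this carbon would read like compound 3.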